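Prenyl removal on a chalcone scaffold: predicting compound 4

The source may hold more compounds than are shown below. What is called first, only, known or untested is meant among the compounds shown, and "the series" means these compounds.

Measured compounds:
Compound 1, `COc1cc(O)c(CC=C(C)C)c(O)c1C(=O)/C=C/c1ccc(Cl)cc1`, gives 16500 nM.
Compound 2, `COc1cc(O)c(CC=C(C)C)c(O)c1C(=O)/C=C/c1cccc([N+](=O)[O-])c1`, gives 16500 nM.
Compound 3, `COc1cc(O)cc(O)c1C(=O)/C=C/c1ccc(Cl)cc1`, gives 17000 nM.

All three values above come from a functional assay on HeLa cells (Homo sapiens) for inhibition, read by MTT assay, with a stated time of 72 h; on this read-out lower numbers stand for stronger inhibition and higher numbers for weaker inhibition. Compound 4, `COc1cc(O)cc(O)c1C(=O)/C=C/c1cccc([N+](=O)[O-])c1`, has not yet been measured in this assay.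

Compound 1 and compound 3 differ by one change: hydrogen in place of 3-methylbut-2-en-1-yl on an aromatic carbon. The step that accompanies it is a 1.0-fold higher number from compound 1 to compound 3 (0.01 log units; within the scatter). Compound 2 and compound 4 differ by the same change, (hydrogen in place of 3-methylbut-2-en-1-yl on an aromatic carbon), and the surroundings of the place are described in the same words for both pairs, so the change is the same in both cases.

The two cores differ as follows: 3-nitrophenyl in place of 4-chlorophenyl on a double-bonded chain carbon bound to a double-bonded chain carbon. The step that goes with this difference is no change at the digits printed from compound 1 to compound 2 (within the scatter), so compound 1 and compound 2 cannot be told apart on this read-out.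

Since the removal of the 3-methylbut-2-en-1-yl group left the value of compound 1 essentially where it was on the way to compound 3, as shown by a 1.0-fold higher number from compound 1 to compound 3 (0.01 log units; within the scatter), the same change from compound 2 to compound 4 is expected to give a step of about a 1.0-fold higher number from compound 2 to compound 4 (0.01 log units; within the scatter). On that basis compound 4 is estimated to give 17000 nM in this assay, with a likely range from 8500 nM to 34000 nM.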

Compound 4, half-maximal inhibitory concentration: 15500 nM
Compound 4: middle estimate off by 1.1-fold (0.04 log units), on the high side; low and high end bracket the measured number.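

In this assay, hydrogen in place of 3-methylbut-2-en-1-yl on the 3-nitrophenyl compound gives a 1.1-fold lower number from compound 2 to compound 4 (0.03 log units; within the scatter), so this pair cannot be told apart on this read-out, just as the 4-chlorophenyl pair could not. The two steps agree: the same change on two cores in this assay, a 1.0-fold higher number (0.01 log units; within the scatter) from compound 1 to compound 3 and a 1.1-fold lower number (0.03 log units; within the scatter) from compound 2 to compound 4, 1.1-fold (0.04 log units) apart, within the scatter of two such steps. This shows that on these two cores the change carries over as a step too small to read, but it does not show how a step of readable size would carry over, nor that the same would hold on any other core in the series.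

The compounds shown leave open whether anything other than hydrogen at this aromatic carbon, such as a longer chain like geranyl, an amine or a carboxylic acid, would shift the value away from that of compound 2 or compound 4. They also leave open whether the removal of 3-methylbut-2-en-1-yl stays as small with groups other than 4-chlorophenyl and 3-nitrophenyl at the far end of the chain, for example a 4-methoxyphenyl group or a 3-hydroxyphenyl group.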